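The source may hold more compounds than are shown below. What is called first, only, known or untested is meant among the compounds shown, and "the series" means these compounds.

Measured so far, in a functional assay on NCI-H322M cells (Homo sapiens) for inhibition, read by sulforhodamine B assay, with a stated time of 48 h; on this read-out higher numbers stand for lower toxicity in this test and lower numbers for higher toxicity in this test:
compound 1 `COc1cc(-c2nn(-c3cccc(NC(=O)Nc4ccc(Cl)c(Cl)c4)c3)cc2-c2ccncc2)ccc1Cl` — > 50000 nM, a limit of the assay
compound 2 `COc1cc(-c2nn(-c3cccc(NC(=O)Nc4cccc(C(F)(F)F)c4)c3)cc2-c2ccncc2)ccc1Cl` — > 50000 nM, a limit of the assay
compound 3 `COc1cc(-c2nn(-c3cccc(NC(=O)Nc4ccc(Cl)c(C(F)(F)F)c4)c3)cc2-c2ccncc2)ccc1Cl` — > 32500 nM, a limit of the assay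

Compound 3 stands only at a limit; the other two values are limits as well (the limit of > 32500 nM in this assay, at which 1 of the 3 values shown sits, (the limit of > 50000 nM in this assay, at which 2 of the 3 values shown sit)), so no ranking among the three is possible. The steps a step that the two limits leave unreadable from compound 1 to compound 3 and a step that the two limits leave unreadable from compound 2 to compound 3 both touch the same aromatic ring that is now removed, yet their size cannot be read. Compound 4 `COc1cc(-c2nn(-c3cccc(NC(=O)c4ccccc4)c3)cc2-c2ccncc2)ccc1Cl` differs from compound 3 by phenyl in place of (4-chloro-3-(trifluoromethyl)phenyl)amino on a carbonyl carbon. The expected step, an estimate of my own, is a step that the limit leaves unreadable from compound 3 to compound 4. The expectation is that compound 4 again returns a limit in this assay, estimated at 50000 nM within 15000 nM to 100000 nM.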

Compound 4, concentration lethal to 50% of the cells: > 100000 nM
Compound 4: no number, only a limit (the forecaster's own chance of this, stated with the estimate: 70%); middle value at least 2.0-fold (0.30 log units) away from the limit.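

In this assay compound 4 gives > 100000 nM, a limit of the assay. The steps to compound 4 from compound 1, compound 2 and compound 3 cannot be read. The compounds shown leave open whether phenyl on the carbonyl carbon changes this read-out at all.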